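From Acetylsulfanyl to 2-Hydroxyethyl on a Shared Core

The compounds below may be only part of what the source reports. "The series", "measured", "known", "first", "only" and "open" are said of these compounds alone.

In a functional assay on P388 cells (Mus musculus) for cytotoxicity (on this read-out lower numbers stand for stronger inhibition and higher numbers for weaker inhibition), compound 1 (`COC(=O)CC[C@@H]1NC(=O)[C@@H](C)NC(=O)[C@@H]2Cc3ccc(OC)c(c3)Oc3ccc(cc3)C[C@@H](C(=O)N2C)N(C)C(=O)[C@H](C)NC(=O)[C@H](Cc2ccc(OC)cc2)N(C)C1=O`) gives 58.9 nM. Among the compounds with values here, on the same core, compound 2 (`COc1ccc(C[C@H]2C(=O)N[C@@H](C)C(=O)N(C)[C@H]3Cc4ccc(cc4)Oc4cc(ccc4OC)C[C@@H](C(=O)N[C@H](C)C(=O)N[C@@H](CSC(C)=O)C(=O)N2C)N(C)C3=O)cc1`) gives 9.77 nM, the lower of the two numbers so far. Within the data shown here, the only measured step, a 6.0-fold lower number from compound 1 to compound 2 (0.78 log units; beyond the scatter), has acetylsulfanyl in place of (methoxycarbonyl)methyl on a saturated chain carbon bound to a saturated ring carbon.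

The next molecule, compound 3 (`COc1ccc(C[C@H]2C(=O)N[C@@H](C)C(=O)N(C)[C@H]3Cc4ccc(cc4)Oc4cc(ccc4OC)C[C@@H](C(=O)N[C@H](C)C(=O)N[C@@H](CCCO)C(=O)N2C)N(C)C3=O)cc1`), changes that same place again: 2-hydroxyethyl in place of acetylsulfanyl on a saturated chain carbon bound to a saturated ring carbon. Put simply, 2-hydroxyethyl stands in place of acetylsulfanyl, so the side chain now ends in a hydroxyl group.

Among the measured compounds shown here, that single step is the only guide, and it shows that a change here can move the number by a modest amount. Compound 3 gives up the acetylsulfanyl group, and compound 1, which also lacks it, stands at 58.9 nM. For the measured compounds named here, still, one pair proves no rule, and no measured compound carries 2-hydroxyethyl. A modest move towards weaker inhibition is therefore expected, with a 3.1-fold higher number from compound 2 to compound 3 (0.49 log units; beyond the scatter) as the estimated step. For compound 3 the estimated value is 30 nM, with an expected range of 8 nM to 120 nM.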

Compound 3, half-maximal inhibitory concentration: 174 nM
For compound 3 the middle estimate is 5.8-fold (0.76 log units) below the measured one; the whole stated range lies below it.
By their numbers in this assay, from the lowest: compound 2; then compound 1; then compound 3.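

In this assay the swap from acetylsulfanyl to 2-hydroxyethyl brings an 18-fold higher number from compound 2 to compound 3 (1.25 log units; beyond the scatter) and counts as a large step, so this place on the side chain can shift the number by much more than the first pair suggested. The hydroxyl-ended chain also does not simply match the ester-bearing chain of compound 1: hydroxymethyl in place of methoxycarbonyl gives a 3.0-fold higher number from compound 1 to compound 3 (0.47 log units; beyond the scatter) as a modest step in the same direction, which leaves compound 3 with the highest number of the three and compound 1 in the middle. No measurement at hand explains why these side chains rank this way.

Compound 2 alone carries sulfur, so these compounds cannot separate the contribution of the sulfur atom from that of its acetyl group, and a free thiol on the same chain would help to tell them apart. On these data alone, whether an amine, a carboxylic acid or a longer chain ending in a hydroxyl group would fall closer to compound 2 or to compound 3 also remains open.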